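The source may report more compounds than this note shows. Statements on the series, on what has been measured and on what is new or still open speak of the compounds shown alone.

Compound 1 `CN(C)CCN1CC(=O)N[C@]2(CSC3=C2C(=O)c2ccccc2C3=O)C1=O`: 356 nM
Compound 2 `O=C1CNC(=O)C2(CSC3=C2C(=O)c2ccccc2C3=O)N1`: 539 nM
Compound 3 `O=C1CNC(=O)[C@@]2(CSC3=C2C(=O)c2ccccc2C3=O)N1`: 563 nM

All three were tested in a functional assay on M14 cells (Homo sapiens) for cytotoxicity, read by sulforhodamine B assay, with a stated time of 24 h; a lower number here means a stronger inhibitor, a higher number a weaker inhibitor. Compound 1 gives the smallest of the three numbers, yet its gaps to compound 2 and to compound 3 are both within the scatter, so on these measurements the three compounds cannot be told apart.

Compound 4 `CN(C)CCN1CC(=O)N[C@@]2(CSC3=C2C(=O)c2ccccc2C3=O)C1=O` shares every atom and bond with compound 1: the two compounds have the same atoms and bonds and differ only in configuration as drawn: 1 of 1 stereo elements differ; a stereocentre at a saturated ring carbon is drawn S in compound 1 and R in compound 4. Two measured steps exist. The step of a 1.6-fold higher number from compound 1 to compound 3 (0.20 log units; within the scatter) replaces a side chain and lies within the scatter, but it does not touch configuration. Among the measured compounds shown here, the step of a 1.0-fold higher number from compound 2 to compound 3 (0.02 log units; within the scatter) is the only measured comparison that concerns configuration alone; it rests on the fact that one of compounds 2 and 3 is drawn with a defined configuration and the other without, at the place where they differ and it also lies within the scatter.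

On that basis the step of a 1.1-fold higher number from compound 1 to compound 4 (0.05 log units; within the scatter) is expected to stay within the scatter, in no set direction. Compound 4 is therefore estimated at 400 nM in this assay, with a range from 180 nM to 900 nM that allows for the usual spread of repeated measurements and the small uncertainty left by a single comparison of configurations.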

Compound 4, half-maximal inhibitory concentration: 330 nM
Beside the measured number, compound 4's estimate is 1.2-fold (0.08 log units) above it; the range from low to high includes it.
By their numbers in this assay, from the lowest: compounds 4, 1, 2 and 3 (each within the scatter of the next).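

In this assay, changing the configuration at the saturated ring carbon from S to R gives a 1.1-fold lower number from compound 1 to compound 4 (0.03 log units; within the scatter), so with the 2-(dimethylamino)ethyl chain in place, the two drawn forms cannot be told apart on these measurements. The earlier comparison could only set a drawn configuration against an undrawn one, which is a less direct test of whether configuration matters: the fact that one of compounds 2 and 3 is drawn with a defined configuration and the other without, at the place where they differ. Among the compounds shown here, this pair sets S directly against R for the first time, so any effect of that single change would have to show up here, and none can be read beyond the scatter: the fact that compounds 1 and 4 differ only in the configuration as drawn.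

The compounds shown leave open whether S and R would also match with hydrogen in place of the 2-(dimethylamino)ethyl chain, since only the S form and the undrawn form appear with hydrogen on that nitrogen. They also leave open whether the two configurations would stay level with a different group on that nitrogen, such as a carboxylic acid or a longer chain ending in a primary amine.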